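This account rests on a few compounds, and the source may have more. Where it says the series, first, only, none or still open, it means among the compounds named here.

Measured so far:
compound 1 `O=C(CN(c1ncnc2c1ncn2C1CCCCO1)C1CC1)NCC(=O)OCc1ccccc1`, 25.9%
compound 2 `O=C(OCc1ccccc1)[C@@H]1CCCN1C(=O)CN(c1nc(Cl)nc2[nH]cnc12)C1CC1`, 43.3%
compound 3 `NCCCC[C@H](NC(=O)CN(c1nc(Cl)nc2[nH]cnc12)C1CC1)C(=O)OCc1ccccc1`, 35.3%

Of the compounds shown here, three have been tested in a functional assay on the whole organism (Tail, strain ICR) with Mus musculus as the target, in the tail flick test, with a stated time of 90 min, at a dose of 25 umol/kg by the oral route; a higher number here means a stronger effect of the compound at the dose given, a lower number a weaker effect. Compound 1 gives 25.9%, the lowest of the three numbers. Its gap to compound 3, which gives 35.3%, lies within the scatter of this assay, so the two cannot be told apart. Its gap to compound 2, which gives 43.3%, lies beyond the scatter.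

Compound 4 `CC(C)(C)OC(=O)NCCCC[C@H](NC(=O)CN(c1ncnc2c1ncn2C1CCCCO1)C1CC1)C(=O)OCc1ccccc1` has not yet been measured. It differs from compound 1 in one place: 4-((tert-butoxycarbonyl)amino)butyl in place of hydrogen on a saturated chain carbon bound to an amide-type nitrogen and a carbonyl carbon. Going by the values given here, no step between measured compounds that differ in only one place is available, so the size of this change has to be guessed from the three numbers alone. Compound 3, which also carries a chain on that carbon, gives 35.3%, and compound 4 is expected to land near that. The step of a number 7.1 percentage points higher from compound 1 to compound 4 (within the scatter) is expected to be small and upward, not beyond the scatter. Compound 4 is therefore estimated at 33%, with a range from 15% to 50%.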

Compound 4, a percentage reported as activity, at one dose (the size of the read-out at that dose, not a potency): 32.9%
For compound 4 the middle estimate is 0.1 percentage points above the measured one; measured number inside the range.
By their numbers in this assay, from the lowest: compounds 1, 4, 3 and 2 (each within the scatter of the next, the first and the last beyond it).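

Going by these compounds alone, at the saturated chain carbon bound to an amide-type nitrogen and a carbonyl carbon, compound 4 gives the first reading of a single change in this assay: 4-((tert-butoxycarbonyl)amino)butyl in place of hydrogen yields a number 7 percentage points higher from compound 1 to compound 4 (within the scatter) and so cannot be told apart from no change. This position on the core of compound 1 therefore carries a chain of 12 heavy atoms with no effect that this read-out can resolve at the one dose given. Nothing available explains this outcome.

As far as these compounds go, it remains open how a free amine at the end of the butyl chain, a carboxylic acid or a longer chain at this carbon would read. Also open, from the compounds shown here alone, is whether the same exchange would read alike on a core with a different substitution.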